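Cyano in place of methoxy: expectation for compound 4

A few compounds are considered here, and "the series" means these few. Any claim that something is new, unique, unknown or untested is made for them only; others in the source may bear on it.

Of the compounds shown here, three have been measured in an assay on isolated protein for inhibition of Ectonucleotide pyrophosphatase/phosphodiesterase family member 1 (Homo sapiens), tested at 10 uM; on this read-out higher numbers stand for more inhibition at the one concentration tested (going by the name of the read-out) and lower numbers for less inhibition. Compound 1 `O=C(CSc1nc2cccnc2[nH]1)Nc1cccc(Br)c1` gives 23%; compound 2 `O=C(CSc1nc2cccnc2[nH]1)Nc1ccccc1` gives 30%; compound 3 `COc1cccc(NC(=O)CSc2nc3cccnc3[nH]2)c1` gives 30%. The three differ only at a single aromatic carbon. Two of the steps, a number 7 percentage points higher from compound 1 to compound 2 (within the scatter) and a number 7 percentage points higher from compound 1 to compound 3 (within the scatter), lie within the scatter, and so does the third, no change at the digits printed from compound 2 to compound 3 (within the scatter). Compound 3 thus stands level with compound 2 at the digits shown, and its gap to compound 1 is within the scatter.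

Compound 4 `N#Cc1cccc(NC(=O)CSc2nc3cccnc3[nH]2)c1` has not been measured. cyano in place of methoxy on an aromatic carbon All three measured steps bear on this change, since each alters the same aromatic carbon, and none moved the read-out beyond the scatter. Going by the values given here, no measured pair shows the cyano group itself. The expected step in this assay is therefore a number 2 percentage points lower from compound 3 to compound 4 (within the scatter), which means no change beyond the scatter. Compound 4 is expected to give about 28%, with a range from 14% to 42%.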

Compound 4, a percentage reported as inhibition, at one concentration (the size of the read-out at that concentration, not a potency): 45%
Beside the measured number, compound 4's estimate is 17 percentage points below it, outside the stated range (above it).
By their numbers in this assay, from the lowest: compounds 1, 2 and 3 (each within the scatter of the next); then compound 4.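

Cyano is the first group at this aromatic carbon to move the read-out beyond the scatter in this assay, with a number 15 percentage points higher from compound 3 to compound 4 (beyond the scatter) and a number 15 percentage points higher from compound 2 to compound 4 (beyond the scatter) and also a number 22 percentage points higher from compound 1 to compound 4 (beyond the scatter) as the steps. The position is therefore not indifferent to substitution: hydrogen, bromo and methoxy remain within the scatter of one another, while compound 4 alone stands beyond the scatter of all the others and holds the highest number of the four. Methoxy and cyano have the same counts of heavy atoms and hydrogen-bond acceptors, so those counts do not account for the separation between them.

No supporting measurement bears on the reason for this gain. It remains open whether a carboxylic acid, a primary amide or an amine on this carbon would match cyano, and a single-concentration read-out gives no potency for any of these compounds.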